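A Second Fluorine on the Sulfone-Bearing Ring

A few compounds are considered here, and "the series" means these few. Any claim that something is new, unique, unknown or untested is made for them only; others in the source may bear on it.

Compound 1 `COc1ccc(-c2c(S(=O)(=O)c3cccc(F)c3)cnc3cc(F)ccc23)cc1` carries a methoxy group and a 3-fluorophenyl attached through a sulfone to the shared core. Within the data shown here, in an ADME assay on microsomes from liver (Homo sapiens) for metabolic stability, tested at 2.5 uM (on this read-out higher numbers stand for fast clearance and lower numbers for slow clearance), compound 1 gives 1.89 mL/min, the higher of the two numbers measured so far. Among the measured compounds shown here, its only measured neighbour is compound 2 `O=S(=O)(c1cccc(F)c1)c1cnc2cc(F)ccc2c1-c1ccc(F)cc1`, which in this assay gives 0.11 mL/min; the step of a 17-fold lower number from compound 1 to compound 2 (1.24 log units; beyond the scatter) comes from a fluoro in place of methoxy on an aromatic carbon.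

Compound 3 `COc1ccc(-c2c(S(=O)(=O)c3cc(F)cc(F)c3)cnc3cc(F)ccc23)cc1` keeps the methoxy group of compound 1 and differs from it by fluoro in place of hydrogen on an aromatic carbon, which cut one bond further out reads as 3-fluorophenyl to 3,5-difluorophenyl. For the measured compounds named here, no measured step touches this ring. Going by the values given here, the one step known, from compound 1 to compound 2, changes a different group, so it tells little about what a second fluorine here will do. The expected step is therefore small, a 1.4-fold lower number from compound 1 to compound 3 (0.13 log units; within the scatter), with no change beyond the scatter in either direction, because a 17-fold lower number from compound 1 to compound 2 (1.24 log units; beyond the scatter) concerns the methoxy group, which compound 3 keeps. For compound 3 the expected value in this assay is 1.4 mL/min, with a range from 0.5 mL/min to 3.8 mL/min.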

Compound 3, intrinsic clearance in a liver preparation (reported as CLH), per the amount of preparation that the assay uses: 1.51 mL/min
For compound 3 the middle estimate is 1.1-fold (0.03 log units) below the measured one; the range from low to high includes it.
By their numbers in this assay, from the lowest: compound 2; then compounds 3 and 1 (each within the scatter of the next).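

In this assay, going from 3-fluorophenyl to 3,5-difluorophenyl gives a 1.3-fold lower number from compound 1 to compound 3 (0.10 log units; within the scatter), so this added fluoro, on an aromatic carbon and meta to a fluoro group, leaves the clearance reading of the methoxy compounds unchanged as far as the scatter can tell. This is the first look at the sulfone-bearing ring among the compounds shown, and its step stands in sharp contrast to a 17-fold lower number from compound 1 to compound 2 (1.24 log units; beyond the scatter), the step at the methoxy group, which lies beyond the scatter. The data at hand hold no measurement that would give a reason for either step.

The compounds shown leave open whether the same second fluorine would be just as silent in the setting of compound 2, which gives 0.11 mL/min and carries a fluoro where compound 1 carries its methoxy group. They also leave open what a different group at this position on the ring, such as an amine or a carboxylic acid, would do to the clearance reading.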